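Trimming a Hydroxymethyl Group from an Amide Side Chain

The compounds below may be only part of what the source reports. "The series", "measured", "known", "first", "only" and "open" are said of these compounds alone.

Compound 3 `CCn1c(C(=O)NC(CO)CCO)ccc1C(CC)(CC)c1ccc(OCCC(O)(CC)CC)c(C)c1` is one of three close relatives tested in an assay on cells for agonist activity at vitamin D3 receptor (Homo sapiens), with a stated time of 96 h; on this read-out higher numbers stand for an effect only at larger amounts of compound and lower numbers for an effect already at smaller amounts. Compound 3 gives 2490 nM, the higher of the two numbers recorded; compound 2 `CCOC(=O)CN(C)C(=O)c1ccc(C(CC)(CC)c2ccc(OCCC(O)(CC)CC)c(C)c2)n1CC` gives 520 nM. For compound 1 `CCn1c(C(=O)Nc2ccc(OC(F)(F)F)cc2)ccc1C(CC)(CC)c1ccc(OCCC(O)(CC)CC)c(C)c1` the result is only a limit, > 10000 nM, as noted in the limit of > 10000 nM in this assay, at which 1 of the 3 values shown sits. Compound 4 `CCn1c(C(=O)NC(C)CO)ccc1C(CC)(CC)c1ccc(OCCC(O)(CC)CC)c(C)c1` differs from compound 3 by hydrogen in place of hydroxymethyl on a saturated chain carbon, two bonds along the chain from an amide-type nitrogen. The measured steps all exchange the entire group on the carbonyl carbon or the amide-type nitrogen: an at least 19-fold lower number from compound 1 to compound 2 (1.28 log units; beyond the scatter), an at least 4.0-fold lower number from compound 1 to compound 3 (0.60 log units; beyond the scatter) and a 4.8-fold higher number from compound 2 to compound 3 (0.68 log units; beyond the scatter). None removes a single small piece as here, so the expected shift is a 1.0-fold higher number from compound 3 to compound 4 (0.00 log units; within the scatter), likely within the scatter. Compound 4 is therefore estimated to give 2500 nM in this assay, with a plausible range from 800 nM to 8000 nM.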

Compound 4, half-maximal effective concentration: 96 nM
The estimate for compound 4 lay 26-fold (1.42 log units) above the measured number; measured number outside the range, below it.
By their numbers in this assay, from the lowest: compound 4; then compound 2; then compound 3. At a limit, above all of these: compound 1.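

Replacing one hydroxymethyl with hydrogen, on a saturated chain carbon two bonds along the chain from an amide-type nitrogen, gives a 26-fold lower number from compound 3 to compound 4 (1.41 log units; beyond the scatter). So this position responds strongly to the loss of a single small piece, which the earlier exchanges of whole groups could not show. The 1-(hydroxymethyl)ethyl group also gives the lowest number against the other two side chains, with a 5.4-fold lower number from compound 2 to compound 4 (0.73 log units; beyond the scatter) and an at least 100-fold lower number from compound 1 to compound 4 (2.01 log units; beyond the scatter). That last step starts from a limit rather than a number: the limit of > 10000 nM in this assay, at which 1 of the 4 values shown sits.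

As far as these compounds go, whether an amine, a carboxylic acid or a longer chain at this carbon would lower the number further stays open. Nothing shown explains why removing this hydroxymethyl has so large an effect.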